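1,3-Benzoxazol-2-yl in place of 1,3-benzothiazol-2-yl

The compounds below may be only part of what the source reports. "The series", "measured", "known", "first", "only" and "open" are said of these compounds alone.

Measured so far in an ADME assay on HepG2 cells (Homo sapiens) for cytotoxicity, with a stated time of 72 h; a higher number here means that more compound is needed for the effect, a lower number that less compound is needed:
Compound 1 `O=C(Nc1cccc(-c2nc3ccccc3o2)c1)c1cc([N+](=O)[O-])ccc1Cl`: > 25000 nM (a limit)
Compound 2 `Cc1ccc(-c2nc3ccccc3s2)cc1NC(=O)c1cc([N+](=O)[O-])ccc1Cl`: > 14000 nM (a limit)
Compound 3 `O=C(Nc1cc(-c2nc3ccccc3s2)ccc1F)c1cc([N+](=O)[O-])ccc1Cl`: > 25000 nM (a limit)

None of these three results is an exact number, so each marks only the end of what the assay could read. Compound 3 stands at the limit of > 25000 nM in this assay, at which 2 of the 3 values shown sit. The remaining result is the limit of > 14000 nM in this assay, at which 1 of the 3 values shown sits.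

Compound 4 `O=C(Nc1cc(-c2nc3ccccc3o2)ccc1F)c1cc([N+](=O)[O-])ccc1Cl` differs from compound 3 in one place, with 1,3-benzoxazol-2-yl in place of 1,3-benzothiazol-2-yl on an aromatic carbon.

The only measured step among these compounds is a step that the two limits leave unreadable from compound 2 to compound 3. It involves a different change, fluoro in place of methyl on an aromatic carbon, and it gives no size to carry over. Compound 1 also carries 1,3-benzoxazol-2-yl. In this assay compound 1 gives > 25000 nM, which is again a limit.

With that evidence, no step beyond the usual scatter is expected, in either direction. The estimated step is a number no higher from compound 3 to compound 4 (the limit leaves the size open). For compound 4 the expected value is 25000 nM, with an estimated range from 14000 nM to 50000 nM.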

Compound 4, half-maximal effective concentration: > 25000 nM
Compound 4 ended at the assay's limit; the forecaster's own chance of this, stated with the estimate: 85%; the middle value sits exactly at the limit.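

Compound 1, compound 3 and compound 4 all end at a limit of the assay rather than an exact number, and the steps from compound 3 to compound 4 and from compound 1 to compound 4 cannot be read. The compounds shown leave open how much of each is needed for the effect in this assay, and whether 1,3-benzoxazol-2-yl in place of 1,3-benzothiazol-2-yl changes that amount at all.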